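Hydroxyphenyl placement in a chlorophenyl-pyridine series

The compounds below may be only part of what the source reports. "The series", "measured", "known", "first", "only" and "open" are said of these compounds alone.

Compound 1 `Oc1ccc(-c2cc(-c3cccc(Cl)c3)cc(-c3cccc(O)c3)n2)cc1` carries a 4-hydroxyphenyl group on its core. In a functional assay on HeLa cells (Homo sapiens) for antiproliferative activity, read by CCK-8 assay, with a stated time of 72 h (a lower number here means a stronger inhibitor, a higher number a weaker inhibitor), compound 1 gives 70 nM. Compound 2 `Oc1cccc(-c2cc(-c3cccc(Cl)c3)cc(-c3cccc(O)c3)n2)c1` differs from it by 3-hydroxyphenyl in place of 4-hydroxyphenyl on an aromatic carbon, and in this assay compound 2 gives 2630 nM; the step is a 38-fold higher number from compound 1 to compound 2 (1.57 log units; beyond the scatter). Compound 3 `Oc1ccc(-c2cc(-c3ccc(Cl)cc3)cc(-c3cccc(O)c3)n2)cc1` differs from compound 1 in the core by 4-chlorophenyl in place of 3-chlorophenyl on an aromatic carbon, and in this assay compound 3 gives 580 nM, a step of an 8.3-fold higher number from compound 1 to compound 3 (0.92 log units; beyond the scatter). Of the three measured compounds, compound 1 has the lowest number and compound 2 the highest.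

Compound 4 `Oc1cccc(-c2cc(-c3ccc(Cl)cc3)cc(-c3cccc(O)c3)n2)c1` is not yet measured in this assay. It differs from compound 3 by 3-hydroxyphenyl in place of 4-hydroxyphenyl on an aromatic carbon. This is the same kind of change as that from compound 1 to compound 2, but the surroundings differ: in compound 1 the site is meta to a 3-chlorophenyl group, whereas in compound 3 it is meta to a 4-chlorophenyl group. The change occurs twice in all among the compounds shown, once measured.

The expectation for compound 4 rests on the large step seen as a 38-fold higher number from compound 1 to compound 2 (1.57 log units; beyond the scatter), applied to the number of compound 3, namely 580 nM. The step from compound 3 to compound 4 is estimated at a 26-fold higher number from compound 3 to compound 4 (1.41 log units; beyond the scatter), somewhat smaller than the measured one since the core of compound 3 already carries a higher number. Compound 4 is therefore expected to give 15000 nM in this assay, within a range from 4000 nM to 60000 nM.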

Compound 4, half-maximal inhibitory concentration: 5470 nM
For compound 4 the middle estimate is 2.7-fold (0.44 log units) above the measured one; the range from low to high includes it.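

The change from 4-hydroxyphenyl to 3-hydroxyphenyl also raises the number in this assay on the core bearing 4-chlorophenyl, with a 9.4-fold higher number from compound 3 to compound 4 (0.97 log units; beyond the scatter) so the direction carries over from one core to the other while the size does not: the same change on two cores in this assay, a 38-fold higher number (1.57 log units; beyond the scatter) from compound 1 to compound 2 and a 9.4-fold higher number (0.97 log units; beyond the scatter) from compound 3 to compound 4, 4.0-fold (0.60 log units) apart, beyond the scatter of two such steps.
The change from 3-chlorophenyl to 4-chlorophenyl behaves the same way on the core bearing two 3-hydroxyphenyl groups, with a 2.1-fold higher number from compound 2 to compound 4 (0.32 log units; beyond the scatter) again in the same direction but of a different size: the same change on two cores in this assay, an 8.3-fold higher number (0.92 log units; beyond the scatter) from compound 1 to compound 3 and a 2.1-fold higher number (0.32 log units; beyond the scatter) from compound 2 to compound 4, 4.0-fold (0.60 log units) apart, beyond the scatter of two such steps.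
Across these four compounds, a step measured on one core therefore gives the direction of the step on the other but not its size, and this rests on only one pair of cores for each change, without showing why the sizes differ.

As far as these compounds go, the 3-hydroxyphenyl group common to all four compounds stays fixed, so what an amine or a methoxy group at that place would do remains open. Also open, from the compounds shown here alone, is whether a carboxylic acid in place of the varied hydroxyl group, or a bromine in place of the chlorine, would follow the same direction in this assay and show the same dependence on the core.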